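Replacing the Methoxyphenyl Amide: an Expectation for Compound 4

The source may report more compounds than this note shows. Statements on the series, on what has been measured and on what is new or still open speak of the compounds shown alone.

compound 1 `COc1ccccc1C(=O)Nc1cccc(-c2oc3cc(-c4ccc(F)cc4)ccc3c(=O)c2O)c1` — 5110 nM
compound 2 `O=C(Nc1cccc(-c2oc3cc(-c4ccc(F)cc4)ccc3c(=O)c2O)c1)c1ccc(C(F)(F)F)cc1` — 29400 nM
compound 3 `Cc1cc(C(=O)Nc2cccc(-c3oc4cc(-c5ccc(F)cc5)ccc4c(=O)c3O)c2)ccc1F` — 7440 nM

All three were run in a functional assay on MDA-MB-231 cells (Homo sapiens) for antiproliferative activity, read by CCK-8 assay, with a stated time of 72 h; on this read-out lower numbers stand for stronger inhibition and higher numbers for weaker inhibition. Compound 1 shows the lowest number of the three, although compound 3 sits within the scatter of it, while compound 2 stands clearly apart (a 5.8-fold higher number from compound 1 to compound 2 (0.76 log units; beyond the scatter)). Compound 4 `Cc1cc(C)cc(C(=O)Nc2cccc(-c3oc4cc(-c5ccc(F)cc5)ccc4c(=O)c3O)c2)c1` carries the change (3,5-dimethylphenyl in place of 2-methoxyphenyl on a carbonyl carbon). Among the measured compounds shown here, two measured steps bear on it: a 1.5-fold higher number from compound 1 to compound 3 (0.16 log units; within the scatter) and a 4.0-fold lower number from compound 2 to compound 3 (0.60 log units; beyond the scatter). Moving to 4-fluoro-3-methylphenyl stayed within the scatter, whereas 4-(trifluoromethyl)phenyl gave a modest step beyond it. The 3,5-dimethylphenyl group resembles the former case more closely than the latter, so compound 4 is expected to show no step beyond the scatter in this assay, written as a 1.4-fold higher number from compound 1 to compound 4 (0.14 log units; within the scatter). Compound 4 is therefore estimated at 7000 nM, with a range from 3500 nM to 16000 nM.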

Compound 4, half-maximal inhibitory concentration: 11900 nM
Compound 4: middle estimate off by 1.7-fold (0.23 log units), on the low side, and the stated range covers the measured number.
By their numbers in this assay, from the lowest: compounds 1, 3 and 4 (each within the scatter of the next, the first and the last beyond it); then compound 2.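

In this assay the 3,5-dimethylphenyl group on the carbonyl carbon gives a 2.3-fold higher number from compound 1 to compound 4 (0.37 log units; beyond the scatter) and thus, unlike 4-fluoro-3-methylphenyl, lands beyond the scatter of 2-methoxyphenyl. Yet a 1.6-fold higher number from compound 3 to compound 4 (0.20 log units; within the scatter) leaves these two groups indistinguishable, and a 2.5-fold lower number from compound 2 to compound 4 (0.39 log units; beyond the scatter) keeps 4-(trifluoromethyl)phenyl clearly apart from both.

No evidence at hand explains these differences between the groups. The compounds shown also leave open whether a pyridyl group or an aliphatic amine on this carbonyl carbon would match or improve on the number of compound 1.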